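Varying the group on the sulfonyl sulfur

The source may report more compounds than this note shows. Statements on the series, on what has been measured and on what is new or still open speak of the compounds shown alone.

Measured compounds:
Compound 1, `Cc1oncc1NS(=O)(=O)c1ccc(F)c2ncc(I)cc12`: in an assay for inhibition of methylcytosine dioxygenase TET2 (Homo sapiens), read by mass spectrometry, with stated times of 30 min and 1 h (a higher number here means a weaker inhibitor, a lower number a stronger inhibitor), compound 1 gives 2100 nM.
Compound 2, `COS(=O)(=O)c1ccc(F)c2ncc(I)cc12`: compound 2 gives > 200000 nM, which is a limit of the assay and not a number.
Compound 3, `O=S(=O)(c1ccc(F)c2ncc(I)cc12)N1CCCC1`: compound 3 gives > 200000 nM, again a limit of the assay.

For the measured compounds named here, compound 1 is therefore the only compound with a read number; the two others sit at the limit of > 200000 nM in this assay, at which 2 of the 3 values shown sit. The step to compound 4 `O=S(=O)(NCc1ccccc1)c1ccc(F)c2ncc(I)cc12` is benzyl in place of 5-methyl-1,2-oxazol-4-yl on a sulfonamide nitrogen. Going by the values given here, two measured steps concern the same sulfonyl sulfur: an at least 95-fold higher number from compound 1 to compound 2 (1.97 log units; beyond the scatter) and an at least 95-fold higher number from compound 1 to compound 3 (1.97 log units; beyond the scatter). Both of these remove the sulfonamide hydrogen along with the aromatic ring, whereas the step to compound 4 keeps that hydrogen and exchanges one ring for another. Among the compounds with values here, they show how far a change at this position can go but do not read directly on a ring exchange of this kind, and no measured pair separates the part played by the hydrogen from that of the ring. The expectation for compound 4 is a weaker number than compound 1, a 5.7-fold higher number from compound 1 to compound 4 (0.76 log units; beyond the scatter), smaller than the two measured losses. Compound 4 is estimated at 12000 nM, range 2500 nM to 120000 nM, with a real chance that the assay reports only a limit.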

Compound 4, half-maximal inhibitory concentration: > 200000 nM
Compound 4 gave a limit, no number; the forecaster's own chance of this, stated with the estimate: 30%; at least 16-fold (1.22 log units) between middle value and limit.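

The sulfonamide hydrogen alone does not preserve a read number at this position: benzyl in place of 5-methyl-1,2-oxazol-4-yl on a sulfonamide nitrogen gives an at least 95-fold higher number from compound 1 to compound 4 (1.97 log units; beyond the scatter). In this assay compound 4 gives > 200000 nM, which is a limit of the assay and not a number. Compound 2 and compound 3 had lost both that hydrogen and the aromatic ring, whereas compound 4 retains the hydrogen and carries an aromatic ring of carbon only, so within this small set a retained hydrogen and an aromatic ring together are not enough, and compound 4 joins the other two at the same ceiling: the limit of > 200000 nM in this assay, at which 3 of the 4 values shown sit.

The compounds shown do not separate the exchange of the five-membered aromatic ring with its hetero atoms for a ring of carbon only from the change in how the ring is attached to the sulfonamide nitrogen, and a phenyl group placed directly on that nitrogen would bear on this question. Nor do they show whether the 5-methyl substituent matters, as an unsubstituted 1,2-oxazol-4-yl group would test, and the size of the loss for compound 4 remains unknown beyond the printed bound.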